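Trading a large group for one iodine atom

The source may hold more compounds than are shown below. What is called first, only, known or untested is meant among the compounds shown, and "the series" means these compounds.

Compound 1 `CC(=O)NC[C@H]1O[C@@H](n2cnc3c(N)nc(F)nc32)[C@H](OC(C)=O)[C@@H]1OC(C)=O` and compound 2 `CC(=O)O[C@@H]1[C@H](OC(C)=O)[C@@H](CN2C(=O)c3ccccc3C2=O)O[C@H]1n1cnc2c(N)nc(F)nc21` share the same core and differ in one group. In an ADME assay on L6 cells (Rattus norvegicus) for inhibition, read by resazurin assay, with a stated time of 72 h (a higher number here means a weaker inhibitor, a lower number a stronger inhibitor), compound 1 gives 138000 nM and compound 2 gives 129000 nM. Among the measured compounds shown here, compound 2 therefore sits within the usual scatter of the only other measured number. Compound 3 `CC(=O)O[C@@H]1[C@H](OC(C)=O)[C@@H](CI)O[C@H]1n1cnc2c(N)nc(F)nc21` has not been measured yet. Its difference from compound 2 is one iodine atom in place of a group of 11 heavy atoms (8 carbon, 1 nitrogen, 2 oxygen; one five-membered non-aromatic ring with 1 hetero atom, one six-membered aromatic ring of carbon only), on a saturated chain carbon bound to a saturated ring carbon. For the measured compounds named here, one measured step bears on this change, because it alters the same place: a 1.1-fold lower number from compound 1 to compound 2 (0.03 log units; within the scatter). That step replaced a group of 4 heavy atoms with a group of 11 heavy atoms. Going by the values given here, no measured compound carries iodine, so it is only a loose guide. No change beyond the scatter is expected in this assay. The expected change is a 1.1-fold lower number from compound 2 to compound 3 (0.03 log units; within the scatter). For compound 3 the estimate is 120000 nM, with an expected range from 50000 nM to 250000 nM.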

Compound 3, half-maximal inhibitory concentration: 6300 nM
For compound 3 the middle estimate is 19-fold (1.28 log units) above the measured one; the measured number lies below the stated range.
By their numbers in this assay, from the lowest: compound 3; then compounds 2 and 1 (each within the scatter of the next).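

In this assay, the place on a saturated chain carbon bound to a saturated ring carbon can clearly move the number, which the acetamido and the larger group of compounds 1 and 2 did not reveal. Putting iodo there gives a 20-fold lower number from compound 2 to compound 3 (1.31 log units; beyond the scatter) and, against acetamido, a 22-fold lower number from compound 1 to compound 3 (1.34 log units; beyond the scatter). No measurement here accounts for this drop.

Iodo is the only halogen shown at this place, so it remains open whether the lower number belongs to iodine specifically or would also appear with chloro, bromo or a small group such as an amine or a hydroxyl. Going by these compounds, whether the same swap would have a similar effect on a different core also remains open.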